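The compounds below may be only part of what the source reports. "The series", "measured", "known", "first", "only" and "open" are said of these compounds alone.

Three compounds that differ in one place on a shared core have been measured in an ADME assay on HCT-116 cells (Homo sapiens) for cytotoxicity, read by CellTiter-Glo, with a stated time of 72 h (a higher number here means a weaker inhibitor, a lower number a stronger inhibitor), so far. Compound 1 (`CC1CCN(C2CCN(S(=O)(=O)c3cccc(N)c3)CC2)CC1`) gives > 5000 nM as a limit of the assay. Compound 2 (`CC1CCN(C2CCN(S(=O)(=O)c3cccc(-c4ccc5ccccc5c4)c3)CC2)CC1`) gives > 5000 nM as a limit too. Compound 3 (`CC1CCN(C2CCN(S(=O)(=O)c3cccc(Br)c3)CC2)CC1`) likewise gives > 5000 nM as a limit and no number. All three therefore stand at one reading, the limit of > 5000 nM in this assay, at which 3 of the 3 values shown sit, and none can be ranked against another. Compound 4 (`CC1CCN(C2CCN(S(=O)(=O)c3cccc(-c4ccccc4)c3)CC2)CC1`) carries phenyl in place of bromo on an aromatic carbon. Within the data shown here, the steps that bear on this change are a step that the two limits leave unreadable from compound 2 to compound 3 and a step that the two limits leave unreadable from compound 1 to compound 3 and a step that the two limits leave unreadable from compound 1 to compound 2 and none of them offers a size to carry over. Because the limit of > 5000 nM in this assay, at which 3 of the 3 values shown sit, holds for all three compounds, no step beyond the scatter is expected in this assay and no direction can be named. The estimated step is a step that the limit leaves unreadable from compound 3 to compound 4 for this change. The expected value for compound 4 is 6000 nM with an estimated range from 2500 nM to 15000 nM and a bare limit is the likeliest report.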

Compound 4, half-maximal inhibitory concentration: > 5000 nM
Compound 4 gave a limit, no number; the forecaster's own chance of this, stated with the estimate: 85%; the middle value is on the limit's open side.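

In this assay compound 4 gives > 5000 nM, a limit of the assay and not a number. No step can be read from compound 4 to compound 1, compound 2 or compound 3: the limit of > 5000 nM in this assay, at which 4 of the 4 values shown sit. The compounds shown leave open whether any group at this place on the shared core gives a measurable value in this assay.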